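Chloro for trifluoromethyl on the anilino ring of compound 2

The compounds below may be only part of what the source reports. "The series", "measured", "known", "first", "only" and "open" are said of these compounds alone.

In a functional assay on NCI-H1975 cells (Homo sapiens) for antiproliferative activity, read by MTT assay, with a stated time of 72 h (on this read-out lower numbers stand for stronger inhibition and higher numbers for weaker inhibition), compound 1 `COc1cc2ncnc(Nc3cc(F)c(F)c(F)c3)c2cc1OCCCCC(=O)Nc1ccc(S(N)(=O)=O)cc1` gives 20000 nM. Within the data shown here, compound 2 `NS(=O)(=O)c1ccc(NC(=S)Nc2ccc3ncnc(Nc4cccc(C(F)(F)F)c4)c3c2)cc1` gives 7590 nM in this assay, the lower of the two numbers so far; the gap to compound 1 is beyond the scatter, though no single-point step connects the two structures. Compound 3 `NS(=O)(=O)c1ccc(NC(=S)Nc2ccc3ncnc(Nc4cccc(Cl)c4)c3c2)cc1` differs from compound 2 in one place only: chloro in place of trifluoromethyl on an aromatic carbon. Among the measured compounds shown here, no measured pair in this set isolates such a swap, so the size of the step cannot be read from the data. The expectation is a step from compound 2 to compound 3 of a 1.1-fold higher number from compound 2 to compound 3 (0.02 log units; within the scatter) in this assay, small and likely within the scatter, since the exchange is a single substituent in the same position. Compound 3 is therefore estimated at 8000 nM in this assay, with a range from 3000 nM to 25000 nM.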

Compound 3, half-maximal inhibitory concentration: 39800 nM
Estimate against measurement, compound 3: 5.0-fold (0.70 log units) below, and the stated range ends below it.
By their numbers in this assay, from the lowest: compound 2; then compounds 1 and 3 (each within the scatter of the next).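

In this assay, among these compounds, the exchange gives the first single-point step, and it is larger than the scatter: a 5.2-fold higher number from compound 2 to compound 3 (0.72 log units; beyond the scatter). With the rest of the structure unchanged, 3-(trifluoromethyl)phenyl and 3-chlorophenyl are therefore not interchangeable here, and this aromatic carbon is a place where the read-out responds to a single substituent, with trifluoromethyl the better of the two groups shown. No measurement at hand accounts for the size or direction of this step.

Still open, going by these compounds, is how a fluoro, a methoxy or a nitrile on the same aromatic carbon would compare with trifluoromethyl and chloro. Also open, on these data alone, is whether the same exchange gives a step of similar size when a urea stands in place of the thiourea.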